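Swapping Thiophene for Furan: Compound 3 to Compound 4

The compounds below may be only part of what the source reports. "The series", "measured", "known", "first", "only" and "open" are said of these compounds alone.

Compound 3 `c1cc(Nc2nccc(-c3cccs3)n2)cc(OCCn2ccnc2)c1` gives 100 nM in a functional assay for inhibition, with Homo sapiens as the target (on this read-out lower numbers stand for stronger inhibition and higher numbers for weaker inhibition), the lowest number among the three measured compounds; compound 1 `c1cc(Nc2nccc(-c3ccco3)n2)cc(-n2ccnc2)c1` gives 800 nM and compound 2 `Cc1cccc(Nc2nccc(-c3ccco3)n2)c1` gives 2100 nM. Compound 4 `c1cc(Nc2nccc(-c3ccco3)n2)cc(OCCn2ccnc2)c1` differs from compound 3 in one place: furan-2-yl in place of thiophen-2-yl on an aromatic carbon. For the measured compounds named here, the only single-point step measured, a 2.6-fold higher number from compound 1 to compound 2 (0.42 log units; beyond the scatter), concerns a different position and does not bear on this swap. Compounds 1 and 2 carry furan-2-yl while compound 3 carries thiophen-2-yl, yet they differ elsewhere as well, so no clean comparison of the two rings exists. The expected step of a 1.6-fold higher number from compound 3 to compound 4 (0.20 log units; within the scatter) is therefore small, at most a slight weakening within or just beyond the scatter. Compound 4 is estimated at 160 nM, within 60 nM to 450 nM.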

Compound 4, half-maximal inhibitory concentration: 200 nM
For compound 4 the middle estimate is 1.3-fold (0.10 log units) below the measured one; measured number inside the range.
By their numbers in this assay, from the lowest: compounds 3 and 4 (each within the scatter of the next); then compound 1; then compound 2.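

Furan-2-yl in place of thiophen-2-yl gives a 2.0-fold higher number from compound 3 to compound 4 (0.30 log units; within the scatter), the first clean comparison of these two rings on this aromatic carbon, and it does not tell them apart. With furan-2-yl held constant, the other varied place can also be read: 2-(1H-imidazol-1-yl)ethoxy gives an 11-fold lower number from compound 2 to compound 4 (1.02 log units; beyond the scatter) when it replaces methyl and a 4.0-fold lower number from compound 1 to compound 4 (0.60 log units; beyond the scatter) when it replaces 1H-imidazol-1-yl, so the larger steps lie at that place. From the compounds shown here alone, whether phenyl in place of furan-2-yl, or an amine in place of the imidazole, would keep these numbers remains open. No evidence is available to explain any of these steps.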